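This account rests on a few compounds, and the source may have more. Where it says the series, first, only, none or still open, it means among the compounds named here.

In an ADME assay on J774 cells (Mus musculus) for cytotoxicity (a higher number here means that more compound is needed for the effect, a lower number that less compound is needed), compound 3 (`COC(=O)c1c[nH]c2ccccc2c1=O`) gives > 20000 nM, which is a limit of the assay and not a number. Compound 2 (`CCCCc1ccc2[nH]cc(C(=O)OC)c(=O)c2c1`) gives > 20000 nM, also a limit. Compound 1 (`COC(=O)c1c[nH]c2cc(OCCOc3ccccc3)c(C)cc2c1=O`) gives > 20000 nM, again a limit. The picture so far is the limit of > 20000 nM in this assay, at which 3 of the 3 values shown sit. Compound 4 (`COC(=O)c1c[nH]c2cc(Cl)ccc2c1=O`) departs from compound 3 by one change, chloro in place of hydrogen on an aromatic carbon. For the measured compounds named here, the only measured step that bears on it is a step that the two limits leave unreadable from compound 2 to compound 3, and its size cannot be read. Going by the values given here, no measured step involves chloro itself, so the expectation rests on the shared core, which has not yet given a number in this assay, even with butyl in compound 2 or the larger substitution in compound 1. No change beyond the scatter is expected, an estimated a number no higher from compound 3 to compound 4 (the limit leaves the size open). For compound 4 the expected value is 20000 nM, with an estimated range from 10000 nM to 40000 nM, and a further limit is the likeliest report.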

Compound 4, half-maximal effective concentration: > 20000 nM
Compound 4 ended at the assay's limit (the forecaster's own chance of this, stated with the estimate: 80%); the middle value sits exactly at the limit.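

For the compounds shown here, compound 3 and compound 4 both stand at a limit of this assay and not at a number, and no step between them can be read. The compounds shown leave open whether any change on the shared core would give a readable value: the limit of > 20000 nM in this assay, at which 4 of the 4 values shown sit.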